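Fluorinated Carboxyphenyl Change Carried onto a Hydroxy Core

This account rests on a few compounds, and the source may have more. Where it says the series, first, only, none or still open, it means among the compounds named here.

The account covers four compounds that share a linker of four saturated carbons between two aryl oxygens and differ in the aryl group at one end and in one substituent on the core. In an assay on HEK293 cells for positive allosteric modulation of metabotropic glutamate receptor 3 (Rattus norvegicus), read by thallium flux, with a stated time of 2.5 min (on this read-out higher numbers stand for larger maximal responses and lower numbers for smaller maximal responses), compound 2 `Cc1c(OCCCCOc2ccccc2C(=O)O)ccc(C(=O)CC(C)C)c1C` gives 30.7%. Compound 1 `Cc1c(OCCCCOc2ccc(F)c(C(=O)O)c2)ccc(C(=O)CC(C)C)c1C` carries 3-carboxy-4-fluorophenyl in place of 2-carboxyphenyl on an oxygen on a saturated carbon; in this assay compound 1 gives 13.8%, so the step of a number 16.9 percentage points lower from compound 2 to compound 1 (beyond the scatter).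

Compound 3 `Cc1c(OCCCCOc2ccccc2C(=O)O)ccc(C(=O)CC(C)C)c1O` differs from compound 2 in the core by hydroxy in place of methyl on an aromatic carbon. In this assay compound 3 gives 28.1%, and the step of a number 2.6 percentage points lower from compound 2 to compound 3 (within the scatter), so the two cores behave alike on this read-out.

Compound 4 `Cc1c(OCCCCOc2ccc(F)c(C(=O)O)c2)ccc(C(=O)CC(C)C)c1O` has not yet been measured. It differs from compound 3 by 3-carboxy-4-fluorophenyl in place of 2-carboxyphenyl on an oxygen on a saturated carbon. This is the same change as that from compound 2 to compound 1, made at the same place, only now on the core that carries hydroxy in place of methyl. Because the step of a number 16.9 percentage points lower from compound 2 to compound 1 (beyond the scatter) was beyond the scatter and the core change a number 2.6 percentage points lower from compound 2 to compound 3 (within the scatter) stayed within it, the writer expects the step of a number 16.6 percentage points lower from compound 3 to compound 4 (beyond the scatter) to be of about the same size as the earlier one. For compound 4 in this assay the expected value is 11.5%, with a likely range from 4% to 22%.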

Compound 4, largest response reached (reported as percent of maximum), in percent of the reference or control that the assay uses: 81.7%
Beside the measured number, compound 4's estimate is 70.2 percentage points below it; measured number above the stated range.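

In this assay, the change from 2-carboxyphenyl to 3-carboxy-4-fluorophenyl did not carry from one core to the other: on the core with hydroxy it gives a number 53.6 percentage points higher from compound 3 to compound 4 (beyond the scatter), and the direction is opposite to that seen on the core with methyl: the same change on two cores in this assay, a number 16.9 percentage points lower (beyond the scatter) from compound 2 to compound 1 and a number 53.6 percentage points higher (beyond the scatter) from compound 3 to compound 4, 70.5 percentage points apart, beyond the scatter of two such steps. Read the other way round, hydroxy in place of methyl, which made no difference beyond the scatter with 2-carboxyphenyl, gives a number 67.9 percentage points higher from compound 1 to compound 4 (beyond the scatter) with 3-carboxy-4-fluorophenyl in place: the same change on two cores in this assay, a number 2.6 percentage points lower (within the scatter) from compound 2 to compound 3 and a number 67.9 percentage points higher (beyond the scatter) from compound 1 to compound 4, 70.5 percentage points apart, beyond the scatter of two such steps. Within these four compounds, the two changes therefore do not add up, and the outcome of each depends on the other, but this rests on one pair of cores and one pair of aryl groups, and it shows neither why they interact nor whether the same holds for any other group.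

The aryl change moves the carboxylic acid and adds fluorine at once, so the compounds shown do not separate these two features. From the compounds shown here alone, it remains open whether a 3-carboxyphenyl group without fluorine would keep the large response on the hydroxy core, and whether a methoxy group in place of the hydroxy would do the same.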